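The compounds below may be only part of what the source reports. "The series", "measured", "known", "first", "only" and "open" are said of these compounds alone.

Measured in an ADME assay on the whole organism (Mus musculus, strain CD1) for metabolic stability, at a dose of 2 mg/kg by the intravenous route; a higher number here means that the compound lasts longer, a lower number that the compound disappears faster:
- Compound 1 `COc1cc(N2C(=O)C3(CCC3)N(c3ccc(OC4CCN(C)CC4)nc3)C2=S)cnc1C#N`: 4.2 h
- Compound 2 `CN1CCC(Oc2ccc(N3C(=S)N(c4cnc(C#N)c(C(F)(F)F)c4)C(=O)C34CCC4)cc2)CC1`: 46.4 h
- Compound 3 `Cc1cc(N2C(=O)C3(CCC3)N(c3ccc(OC4CCNCC4)nc3)C2=S)cnc1C#N`: 3 h

Compound 2 stands highest of the three, and its gaps to compound 1 and compound 3 both lie beyond the scatter. Compound 4 `N#Cc1ncc(N2C(=O)C3(CCC3)N(c3ccc(CN4CCNCC4)cc3)C2=S)cc1C(F)(F)F` keeps the rest of compound 2 but has (piperazin-1-yl)methyl in place of (1-methylpiperidin-4-yl)oxy on an aromatic carbon, para to a large group: (piperazin-1-yl)methyl in place of (1-methylpiperidin-4-yl)oxy on an aromatic carbon. Going by the values given here, no measured pair isolates this change, so the expectation is tentative. Like compound 4, compound 3 has a hydrogen-bond donor in that side group, and compound 3 gives 3 h, though it also differs elsewhere. A downward move is therefore expected, probably beyond the scatter, with an estimated step of a 3.9-fold lower number from compound 2 to compound 4 (0.59 log units; beyond the scatter). For compound 4, the estimated half-life is 12 h, within an expected range of 3 h to 40 h.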

Compound 4, half-life: 12.1 h
For compound 4 the middle estimate is 1.0-fold (0.00 log units) below the measured one, within the range that was stated.
By their numbers in this assay, from the lowest: compounds 3 and 1 (each within the scatter of the next); then compound 4; then compound 2.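

Going by these compounds alone, this pair gives the first direct reading at this position: with the rest of the molecule unchanged, putting (piperazin-1-yl)methyl in place of (1-methylpiperidin-4-yl)oxy gives, in this assay, a 3.8-fold lower number from compound 2 to compound 4 (0.58 log units; beyond the scatter). The side group on this aromatic carbon can therefore alter the half-life on its own, without any change elsewhere in the molecule. Nothing measured here explains the drop. From the compounds shown here alone, the swap changes the link to the aromatic ring and the ring itself together, so their separate contributions remain unknown. A (4-methylpiperazin-1-yl)methyl group would show whether the hydrogen-bond donor matters.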